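The source may report more compounds than this note shows. Statements on the series, on what has been measured and on what is new or still open speak of the compounds shown alone.

Measured compounds:

Compound 1, `COc1cc(-c2cc(/C=C/C(=O)c3ccc(N)cc3)[nH]n2)cc(OC)c1OC`: 28%
Compound 2, `COc1ccc(-c2cc(/C=C/C(=O)c3ccc(N)cc3)[nH]n2)cc1OC`: 77%
Compound 3, `COc1cc(C(=O)/C=C/c2cc(-c3cc(OC)c(OC)c(OC)c3)n[nH]2)cc(OC)c1OC`: -67%

These three compounds were tested in a functional assay on HOP-92 cells (Homo sapiens) for cytotoxicity, read by sulforhodamine B assay, with a stated time of 48 h, tested at 10 uM; on this read-out lower numbers stand for a stronger effect and higher numbers for a weaker effect at the one concentration tested. Compound 1 gives 28%, and compound 2, which carries one methoxy group fewer, gives 77%. That single change, (hydrogen in place of methoxy on an aromatic carbon), produced a number 49 percentage points higher from compound 1 to compound 2 (beyond the scatter), meaning the compound with the hydrogen in place of the methoxy had a clearly weaker effect on the cells. Compound 3 stands apart from both: in this assay compound 3 gives -67%, the lowest number of the three and the strongest effect, with compound 1 nearest to it and compound 2 furthest away. How the core of compound 3 differs from the core of compound 1 is not broken down here.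

Compound 4, `COc1ccc(-c2cc(/C=C/C(=O)c3cc(OC)c(OC)c(OC)c3)[nH]n2)cc1OC`, has not yet been measured. Among the compounds with values here, it is related to compound 3 by the change (hydrogen in place of methoxy on an aromatic carbon), which is the same change as the one between compound 1 and compound 2, made at the same kind of place. Because the earlier step was a number 49 percentage points higher from compound 1 to compound 2 (beyond the scatter), a weakening of similar size is expected here, so the expected step is a number 47 percentage points higher from compound 3 to compound 4 (beyond the scatter). Since compound 3 starts from such a strong effect, compound 4 is still expected to show a marked effect, estimated at -20%, in a range from -60% to 30%.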

Compound 4, a percentage reported as activity, at one concentration (the size of the read-out at that concentration, not a potency): -25%
Compound 4: the middle estimate sits 5 percentage points above what was measured; the measured number falls inside the stated range.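

In this assay, putting hydrogen in place of a methoxy group on the aromatic ring gave a number 42 percentage points higher from compound 3 to compound 4 (beyond the scatter), a clear weakening of the effect on the cells, and the size of this step matches the earlier one on the other core: the same change on two cores in this assay, a number 49 percentage points higher (beyond the scatter) from compound 1 to compound 2 and a number 42 percentage points higher (beyond the scatter) from compound 3 to compound 4, 7 percentage points apart, within the scatter of two such steps In these two pairs, then, the change carried over from one core to the other, with the effect falling by a similar amount even though the two pairs start from very different numbers. This does not show that the same step would appear on any further core, since two pairs are a small sample, and it does not explain why losing the methoxy group weakens the effect, nor does a reading at a single concentration in one cell line give a potency.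

The compounds shown carry only methoxy or hydrogen at this place, so it remains open how a hydroxyl group, a chlorine atom or a longer ethoxy chain would behave there. Also open, as far as these compounds go, is whether the step keeps its size at other concentrations or in other cell lines.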